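Azidomethyl added to the sugar ring of compound 2

A few compounds are considered here, and "the series" means these few. Any claim that something is new, unique, unknown or untested is made for them only; others in the source may bear on it.

The series begins with two sugar-bearing compounds that share a core. Compound 1 `C=C(C)[C@@H]1CC=C(CN(OC)C2O[C@H](CO)[C@@H](O)[C@H](O)[C@H]2N=[N+]=[N-])CC1` and compound 2 `C=C(C)[C@@H]1CC=C(CN(OC)C2OC[C@@H](N=[N+]=[N-])[C@H](O)[C@H]2O)CC1` were both tested in a functional assay on A549 cells (Homo sapiens) for cytotoxicity, read by resazurin assay, with a stated time of 48 h; a higher number here means a weaker inhibitor, a lower number a stronger inhibitor. In this assay compound 1 gives 221000 nM, while compound 2 gives 76000 nM. Compound 2 thus stands at the lowest of the two numbers, and compound 1, the nearest, sits at a number that differs by more than the usual scatter. Among the measured compounds shown here, no single-point step between the two has been worked out, so only their two values can be compared.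

The unmeasured compound 3 `C=C(C)[C@@H]1CC=C(CN(OC)C2O[C@H](CN=[N+]=[N-])[C@@H](N=[N+]=[N-])[C@H](O)[C@H]2O)CC1` is built from compound 2 by one change: azidomethyl in place of hydrogen on a saturated ring carbon. The new group sits on a saturated ring carbon of the ring that carries the azido and hydroxy groups. For the measured compounds named here, nothing among the measured compounds tells how such an addition moves the numbers here, so no large step is expected in either direction.

For compound 3 the estimated step of a 1.3-fold lower number from compound 2 to compound 3 (0.10 log units; within the scatter) is small and kept within the scatter. Compound 3 is expected to give 60000 nM, with a range from 20000 nM to 200000 nM.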

Compound 3, half-maximal inhibitory concentration: 44000 nM
Compound 3: the middle estimate sits 1.4-fold (0.13 log units) above what was measured, and the stated range covers the measured number.
By their numbers in this assay, from the lowest: compounds 3 and 2 (each within the scatter of the next); then compound 1.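

In this assay, azidomethyl in place of hydrogen on the saturated ring carbon next to the ring oxygen gives a 1.7-fold lower number from compound 2 to compound 3 (0.24 log units; within the scatter), so compound 3 and compound 2 cannot be told apart in this read-out. Among the compounds shown here, this is the first single-change step, and it shows that this position can carry azidomethyl with no shift beyond the scatter, something the two earlier compounds could not show, as they offered no such step. No supporting information bears on this result, so the near-identical numbers remain without an explanation.

The compounds shown leave open whether this position would tolerate other groups equally well, such as a simple methyl, an aminomethyl, a carboxylic acid or a longer chain, any of which might move the number beyond the scatter or leave it in place. They also leave open whether azidomethyl would give a similarly small step on the ring carbons that bear the hydroxy groups, or on a compound with a different sugar ring pattern.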